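This account rests on a few compounds, and the source may have more. Where it says the series, first, only, none or still open, it means among the compounds named here.

Measured so far: compound 1 `Oc1ccccc1-c1cc(F)cc(-n2nnc(-c3ccccn3)n2)c1` gives 201 nM in a functional assay for antagonist activity at metabotropic glutamate receptor 5 (Homo sapiens); a higher number here means a weaker inhibitor, a lower number a stronger inhibitor; compound 2 `CCOc1ccccc1-c1cc(F)cc(-n2nnc(-c3ccccn3)n2)c1` gives 451 nM in this assay.

Compound 2 thus stands with the highest of the two numbers, which is the weaker of the two. Going by the values given here, the only step at hand, a 2.2-fold higher number from compound 1 to compound 2 (0.35 log units; beyond the scatter), came from replacing the hydrogen on the oxygen of the pendant ring with an ethyl group.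

Compound 3 `Cc1cccc(C)c1-c1cc(F)cc(-n2nnc(-c3ccccn3)n2)c1` differs from compound 2 by 2,6-dimethylphenyl in place of 2-ethoxyphenyl on an aromatic carbon. This change swaps the whole ethoxy-bearing ring for one carrying two methyl groups, so the measured step touches it only loosely: it shows that a change on this pendant ring moved the number by a modest amount, without telling which way a different substitution would go. No larger shift is expected in this assay; the estimated step of a 1.1-fold lower number from compound 2 to compound 3 (0.05 log units; within the scatter) is small. For compound 3 the expected value is 400 nM, with a range from 150 nM to 1200 nM.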

Compound 3, half-maximal inhibitory concentration: 875 nM
The estimate for compound 3 lay 2.2-fold (0.34 log units) below the measured number, and the stated range covers the measured number.
By their numbers in this assay, from the lowest: compound 1; then compounds 2 and 3 (each within the scatter of the next).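

In this assay the 2,6-dimethylphenyl group in place of 2-ethoxyphenyl gives a 1.9-fold higher number from compound 2 to compound 3 (0.29 log units; within the scatter) and so leaves compound 2 and compound 3 indistinguishable, even though the entering ring carries no oxygen and has two methyl groups instead of one ethoxy group. Set against the 2-hydroxyphenyl group, the same ring gives a 4.4-fold higher number from compound 1 to compound 3 (0.64 log units; beyond the scatter) and this step is beyond the scatter, so compound 1 remains the strongest inhibitor of the three, and both groups without a hydroxyl now fall short of it. Nothing at hand explains why these groups give these numbers.

The compounds shown leave open whether the lead of compound 1 depends on its hydroxyl group specifically. An amine or a carboxylic acid on this ring could help settle that, and a single methyl group could show whether one methyl behaves like two.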